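From Phenyl to Pyridin-3-yl: Compound 3 and Compound 4

The source may hold more compounds than are shown below. What is called first, only, known or untested is meant among the compounds shown, and "the series" means these compounds.

In a functional assay on KB-V1 cells (Homo sapiens) for cytotoxicity, read by MTT assay, with a stated time of 72 h (on this read-out lower numbers stand for stronger inhibition and higher numbers for weaker inhibition), compound 1 (`O=C1Nc2ccccc2/C1=N/NC(=S)Nc1cccc2ccccc12`) gives 2210 nM and compound 2 (`O=C1Nc2ccccc2/C1=N/NC(=S)Nc1ccc2c(c1)CCC2`) gives 2850 nM while compound 3 (`O=C1Nc2ccccc2/C1=N/NC(=S)Nc1ccccc1`) gives 1470 nM on the same read-out. Compound 3 lies within the usual scatter of both others, so these three numbers cannot be ranked. Compound 4 (`O=C1Nc2ccccc2/C1=N/NC(=S)Nc1cccnc1`) has pyridin-3-yl in place of phenyl on an amide-type nitrogen. Among the measured compounds shown here, no pair of measured compounds shows this kind of swap, so any forecast is uncertain. A small move toward weaker inhibition in this assay is expected, not clearly beyond the scatter, with an estimated step of a 1.9-fold higher number from compound 3 to compound 4 (0.28 log units; within the scatter) overall. The estimated value for compound 4 is 2800 nM (expected range 1100 nM to 7500 nM).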

Compound 4, half-maximal inhibitory concentration: > 50000 nM
Compound 4 gave a limit, no number; the forecaster's own chance of this, stated with the estimate: 8%; middle value at least 17-fold (1.25 log units) from the limit.
By their numbers in this assay, from the lowest: compounds 3, 1 and 2 (each within the scatter of the next). At a limit, above all of these: compound 4.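

Compounds 1, 2 and 3 carry different groups on this amide-type nitrogen, yet their values stay within the scatter of one another. Pyridin-3-yl in place of phenyl, which exchanges one ring carbon for a nitrogen, gives an at least 34-fold higher number from compound 3 to compound 4 (1.53 log units; beyond the scatter), so this place is far more sensitive to that single atom change than the earlier compounds suggested. Compound 4 stands at a limit of the assay, not at a number: the limit of > 50000 nM in this assay, at which 1 of the 4 values shown sits.

The compounds shown leave open how pyridin-4-yl would read at this place. They also leave open what lies behind the large step, and how large it truly is.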